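Ring closure of the amine substituent to a six-membered ring

This account rests on a few compounds, and the source may have more. Where it says the series, first, only, none or still open, it means among the compounds named here.

Compound 2 `CCN(CCN)c1ccc(Nc2cc(NC3CC3)n3ncc(C#N)c3n2)cc1NC(C)=O` gives 5 mL.min-1.g-1 in an ADME assay on liver for metabolic stability, with Liver microsome (Homo sapiens) as the target, using microsomes (a lower number here means slower removal, a higher number faster removal of the compound), the lowest of the two numbers in the set; compound 1 `CC(=O)Nc1cc(Nc2cc(NC3CC3)n3ncc(C#N)c3n2)ccc1NCCCO` gives 21 mL.min-1.g-1, and the step of a 4.2-fold lower number from compound 1 to compound 2 (0.62 log units; beyond the scatter) lies beyond the scatter. Compound 3 `CC(=O)Nc1cc(Nc2cc(NC3CC3)n3ncc(C#N)c3n2)ccc1N1CC[C@H](N)C1` reaches only a limit of the assay, < 3 mL.min-1.g-1, namely (the limit of < 3 mL.min-1.g-1 in this assay, at which 1 of the 3 values shown sits). The step of an at least 1.6-fold lower number from compound 2 to compound 3 (0.22 log units; that floor lies within the scatter) has its floor inside the scatter. Compound 4 `CC(=O)Nc1cc(Nc2cc(NC3CC3)n3ncc(C#N)c3n2)ccc1N1CCC[C@H](N)C1` differs from compound 2 by a group of 7 heavy atoms (5 carbon, 2 nitrogen; one six-membered non-aromatic ring with 1 hetero atom) in place of a group of 6 heavy atoms (4 carbon, 2 nitrogen; no ring), on an aromatic carbon. Going by the values given here, the only measured step that bears on this is the closure to 3-aminopyrrolidin-1-yl, whose floor sat within the scatter; the six-membered counterpart is expected to behave alike, so a downward step a 1.7-fold lower number from compound 2 to compound 4 (0.22 log units; within the scatter) of at most modest size is expected. Compound 4 is therefore estimated at 3 mL.min-1.g-1, within 1.5 mL.min-1.g-1 to 6 mL.min-1.g-1, with a fair chance that only a limit is reported.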

Compound 4, intrinsic clearance in microsomes: < 3 mL.min-1.g-1
Compound 4 ended at the assay's limit; the forecaster's own chance of this, stated with the estimate: 50%; the middle value lies on the limit itself.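

In this assay the 3-aminopiperidin-1-yl group takes compound 4 to a limit of the assay, as 3-aminopyrrolidin-1-yl did for compound 3, so both ring sizes end there. The change from the open chain gives an at least 1.6-fold lower number from compound 2 to compound 4 (0.22 log units; that floor lies within the scatter), while the change from (3-hydroxypropyl)amino gives an at least 7.0-fold lower number from compound 1 to compound 4 (0.84 log units; beyond the scatter). The step between compound 3 and compound 4 cannot be read, because both stand at the limit: the limit of < 3 mL.min-1.g-1 in this assay, at which 2 of the 4 values shown sit.

Still open, on these data alone, is whether the amino group on the ring is needed to reach this limit. A 3-hydroxypiperidin-1-yl group at the same position would test that.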